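The source may report more compounds than this note shows. Statements on the series, on what has been measured and on what is new or still open speak of the compounds shown alone.

Compounds measured so far:
compound 1, `CC(=O)c1ccc(/C=C2\CCCN=C2c2cccnc2)cc1`: 4490 nM
compound 2, `Cc1cc(/C=C2\CCCN=C2c2cccnc2)cc(C)c1O`: 360 nM

Both compounds were tested in an assay on membranes from brain for displacement of a labelled ligand from Neuronal acetylcholine receptor; alpha4/beta2 (Rattus norvegicus), with a stated time of 3 h; a higher number here means a weaker inhibitor, a lower number a stronger inhibitor. Compound 1 holds the highest of the two numbers, so it is the weaker binder of the pair. Its nearest neighbour is compound 2, whose value is lower by an amount that lies well beyond the usual scatter of this assay, so the difference between compound 1 and compound 2 is a real one.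

The next compound is compound 3, `CC(C)(C)C(=O)Oc1ccc(/C=C2\CCCN=C2c2cccnc2)cc1`. It is built from compound 1 by a single exchange: ((tert-butyl)carbonyl)oxy in place of acetyl on an aromatic carbon. The acetyl group leaves and the ((tert-butyl)carbonyl)oxy group takes its place on the same aromatic carbon, bringing more heavy atoms and one more hydrogen-bond acceptor.

Going by the values given here, no measured pair in this set shows what such an exchange does in this assay, so the direction of the step is open. The expected step of a 1.8-fold lower number from compound 1 to compound 3 (0.25 log units; within the scatter) is small, within or just beyond the scatter, with a slight lean toward a lower number. Compound 3 is therefore estimated at 2500 nM, in a range from 600 nM to 10000 nM.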

Compound 3, inhibition constant: 830 nM
Estimate against measurement, compound 3: 3.0-fold (0.48 log units) above, within the range that was stated.
By their numbers in this assay, from the lowest: compound 2; then compound 3; then compound 1.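

Going by these compounds alone, this is the first step that can be read at this position, on an aromatic carbon para to a large group: in this assay, ((tert-butyl)carbonyl)oxy in place of acetyl gives a 5.4-fold lower number from compound 1 to compound 3 (0.73 log units; beyond the scatter). The position therefore tolerates a group with more heavy atoms than acetyl, and with this exchange the number falls rather than rises, a change larger than repeat measurements would produce. No measurement available here bears on why the number falls.

This single step changes the acetyl group for one with an added oxygen and a tert-butyl part at the same time, so it cannot show how much each of these contributes. It also leaves open what a methoxy group, an amine or a carboxylic acid would do on the same aromatic carbon, and whether a group larger than ((tert-butyl)carbonyl)oxy would lower the number further or raise it again.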